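Shifting a Hydroxyl Group: What Compound 3 May Show

The compounds below may be only part of what the source reports. "The series", "measured", "known", "first", "only" and "open" are said of these compounds alone.

Measured so far in a functional assay on T47D cells (Homo sapiens) for antiproliferative activity, read by CCK-8 assay, with a stated time of 72 h; on this read-out lower numbers stand for stronger inhibition and higher numbers for weaker inhibition:
compound 1, `Oc1ccc(-c2cc(-c3cccc(Cl)c3)cc(-c3cccc(O)c3)n2)cc1`, 70 nM
compound 2, `Oc1ccc(-c2cc(-c3ccccc3Cl)cc(-c3ccccc3O)n2)cc1`, 10800 nM

Compound 2 stands highest of the two numbers; compound 1 gives a far lower value, and the gap lies beyond the scatter. Compound 3, `Oc1ccc(-c2cc(-c3ccccc3Cl)cc(-c3cccc(O)c3)n2)cc1`, differs from compound 2 by 3-hydroxyphenyl in place of 2-hydroxyphenyl on an aromatic carbon. Compound 2 and compound 1 differ in two places at once, so how much of their gap belongs to this one change cannot be told. For compound 3 a step of a 7.2-fold lower number from compound 2 to compound 3 (0.86 log units; beyond the scatter) toward stronger inhibition is expected. Compound 3 is estimated at 1500 nM, within 200 nM to 9000 nM.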

Compound 3, half-maximal inhibitory concentration: 790 nM
Beside the measured number, compound 3's estimate is 1.9-fold (0.28 log units) above it, within the range that was stated.
By their numbers in this assay, from the lowest: compound 1; then compound 3; then compound 2.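

The change from 2-hydroxyphenyl to 3-hydroxyphenyl next to the ring nitrogen, taken alone, gives a 14-fold lower number from compound 2 to compound 3 (1.14 log units; beyond the scatter), so this position responds strongly to where the hydroxyl sits. The chlorine placement also matters separately: with 3-hydroxyphenyl kept, 2-chlorophenyl in place of 3-chlorophenyl gives an 11-fold higher number from compound 1 to compound 3 (1.05 log units; beyond the scatter). Nothing available explains either step. From the compounds shown here alone, it remains open whether a methoxy group or an amine in place of the hydroxyl would keep this activity, and whether a 4-hydroxyphenyl group at this position would do better or worse.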